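Swapping the Dichlorophenyl Ring for a Chloro-Trifluoromethyl Ring

A few compounds are considered here, and "the series" means these few. Any claim that something is new, unique, unknown or untested is made for them only; others in the source may bear on it.

Within the data shown here, in a functional assay on MCF7 cells (Homo sapiens) for inhibition (on this read-out lower numbers stand for stronger inhibition and higher numbers for weaker inhibition), compound 2 `CC/C(=C(/c1ccc(/C=C/C(=O)O)cc1)c1cc2ccccc2[nH]1)c1cc(Cl)ccc1Cl` gives 71 nM, the higher of the two numbers known here, while compound 1 `CC/C(=C(/c1ccc(/C=C/C(=O)O)cc1)c1cc2ccccc2[nH]1)c1ccc(Cl)cc1Cl` gives 11 nM. Compound 3 `CC/C(=C(/c1ccc(/C=C/C(=O)O)cc1)c1cc2ccccc2[nH]1)c1ccc(Cl)c(C(F)(F)F)c1` is not yet measured. It differs from compound 2 in one place: 4-chloro-3-(trifluoromethyl)phenyl in place of 2,5-dichlorophenyl on a double-bonded chain carbon bound to a double-bonded chain carbon and a saturated chain carbon. Among the measured compounds shown here, one measured step bears on this ring: a 6.5-fold higher number from compound 1 to compound 2 (0.81 log units; beyond the scatter), showing that where the chlorines sit shifts the read-out beyond the scatter. For the measured compounds named here, no step tests a trifluoromethyl group, so the size is uncertain. A modest step toward lower numbers is expected, a 2.4-fold lower number from compound 2 to compound 3 (0.37 log units; beyond the scatter), partly because compound 1 gives 11 nM. Compound 3 is therefore estimated at 30 nM, within 8 nM to 120 nM.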

Compound 3, half-maximal inhibitory concentration: 2200 nM
Estimate against measurement, compound 3: 73-fold (1.87 log units) below, outside the stated range (above it).
By their numbers in this assay, from the lowest: compound 1; then compound 2; then compound 3.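

In this assay, replacing either dichlorophenyl ring with 4-chloro-3-(trifluoromethyl)phenyl gives a 31-fold higher number from compound 2 to compound 3 (1.49 log units; beyond the scatter) and a 200-fold higher number from compound 1 to compound 3 (2.30 log units; beyond the scatter). Both steps are larger than a 6.5-fold higher number from compound 1 to compound 2 (0.81 log units; beyond the scatter), so among these three compounds, the change to this ring shifts the read-out more than the move between the two dichlorophenyl patterns. Nothing available explains the rise.

The compounds shown do not separate the effect of adding trifluoromethyl from that of changing where the chlorine sits. Going by these compounds, how an unsubstituted phenyl ring or a methoxy-bearing phenyl ring would read out at this position also remains open.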